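A few compounds are considered here, and "the series" means these few. Any claim that something is new, unique, unknown or untested is made for them only; others in the source may bear on it.

Series notes. In a functional assay on DU-145 cells (Homo sapiens) for antiproliferative activity, read by WST assay, with a stated time of 48 h, tested at 1 uM (a higher number here means a stronger effect of the compound at the concentration tested, a lower number a weaker effect), compound 1 `Cc1[nH]n(-c2nc3cc(Cl)ccc3[nH]2)c(=O)c1Cc1ccccc1` gives 86%, compound 2 `Cc1ccc2[nH]c(-n3[nH]c(C)c(Cc4ccccc4)c3=O)nc2c1` gives 35% and compound 3 `Cc1ccc2[nH]c(-n3[nH]c(C)c(C)c3=O)nc2c1` gives -11%. Compound 2 stands second of the three: a number 51 percentage points lower from compound 1 to compound 2 (beyond the scatter), and a number 46 percentage points lower from compound 2 to compound 3 (beyond the scatter). Compound 4 `Cc1[nH]n(-c2nc3cc(C(F)(F)F)ccc3[nH]2)c(=O)c1Cc1ccccc1` differs from compound 2 by trifluoromethyl in place of methyl on an aromatic carbon. The step that bears on this is the one at the same aromatic carbon, a number 51 percentage points lower from compound 1 to compound 2 (beyond the scatter); the other step, a number 46 percentage points lower from compound 2 to compound 3 (beyond the scatter), lies elsewhere and shows only that the read-out moves widely within this set. A large step is therefore expected here, most likely upward, a number 30 percentage points higher from compound 2 to compound 4 (beyond the scatter). Compound 4 is estimated at 65% in this assay, within a range from 35% to 90%.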

Compound 4, a percentage reported as inhibition, at one concentration (the size of the read-out at that concentration, not a potency): 78%
Compound 4: middle estimate off by 13 percentage points, on the low side, and the stated range covers the measured number.
By their numbers in this assay, from the lowest: compound 3; then compound 2; then compounds 4 and 1 (each within the scatter of the next).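

At this aromatic carbon in this assay, the loss seen with methyl is now reversed by a second group, a number 43 percentage points higher from compound 2 to compound 4 (beyond the scatter), so the low read-out of compound 2 does not belong to chloro alone as a point of comparison. Trifluoromethyl and chloro cannot be told apart here, a number 8 percentage points lower from compound 1 to compound 4 (within the scatter). No measured property explains why methyl parts from these two groups. From the compounds shown here alone, whether an amine, a methoxy group or a carboxylic acid at this carbon would stay with chloro and trifluoromethyl or fall with methyl remains open. Also open, going by these compounds, is how much of the read-out of compound 4 depends on its phenyl.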